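The source may report more compounds than this note shows. Statements on the series, on what has been measured and on what is new or still open speak of the compounds shown alone.

In an ADME assay on microsomes from liver (Rattus norvegicus) for metabolic stability, read by LC-MS, with a stated time of 10 min, tested at 0.5 uM (on this read-out lower numbers stand for a less stable compound and higher numbers for a more stable compound), compound 2 (`c1ccc2c(c1)CN[C@H](CN(CCCN1CCNCC1)[C@H]1CCCc3cccnc31)C2`) gives 88%, the highest of the three numbers, against compound 1 (`c1ccc2c(c1)CN[C@@H](CN(CC1CCNCC1)[C@H]1CCCc3cccnc31)C2`) at 65% and compound 3 (`c1ccc2c(c1)CN[C@@H](CN(CCCN1CCN(C3CC3)CC1)[C@H]1CCCc3cccnc31)C2`) at 2%. The change leading to compound 4 (`c1cnc2c(c1)CCC[C@@H]2N(CCCN1CCNCC1)Cc1nc2ccccc2[nH]1`) is 1H-benzimidazol-2-yl in place of 1,2,3,4-tetrahydroisoquinolin-3-yl on a saturated chain carbon bound to an amine nitrogen. Among the measured compounds shown here, the one measured step, a number 63 percentage points lower from compound 1 to compound 3 (beyond the scatter), is large but replaces a different group, so no measured step covers this place. For the measured compounds named here, it shows only that numbers in this assay can move far. With compound 2 at 88%, little room for a rise remains, so a moderate fall is expected. The estimated size is a number 28 percentage points lower from compound 2 to compound 4 (beyond the scatter). The expected value for compound 4 is 60%, with an estimated range of 25% to 90%.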

Compound 4, percent of the compound remaining: 29%
Estimate against measurement, compound 4: 31 percentage points above; low and high end bracket the measured number.
By their numbers in this assay, from the lowest: compound 3; then compound 4; then compound 1; then compound 2.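

In this assay, the group on a saturated chain carbon bound to an amine nitrogen strongly affects the read-out: 1H-benzimidazol-2-yl in place of 1,2,3,4-tetrahydroisoquinolin-3-yl gives a number 59 percentage points lower from compound 2 to compound 4 (beyond the scatter). The two groups have the same counts of hydrogen-bond donors and acceptors, so those counts do not account for the step. No measurement shown explains the fall. From the compounds shown here alone, whether the fall follows the five-membered aromatic ring or its second nitrogen stays open. A 1H-indol-2-yl group at this place would separate the two.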